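Swapping a Hydroxy for a Benzyloxycarbonyl on Compound 2

The compounds below may be only part of what the source reports. "The series", "measured", "known", "first", "only" and "open" are said of these compounds alone.

Of the compounds shown here, two on a shared core have so far been tested in a functional assay on the whole organism (Tail, strain ICR) with Mus musculus as the target, in the tail flick test, with a stated time of 120 min, at a dose of 25 umol/kg by the oral route; a lower number here means a weaker effect, a higher number a stronger effect of the compound at the dose given. Compound 1 `O=C(CN(c1ncnc2c1ncn2C1CCCCO1)C1CC1)NCC(=O)OCc1ccccc1` gives 17.2%. Compound 2 `O=C(CN(c1ncnc2c1ncn2C1CCCCO1)C1CC1)N[C@@H](CO)C(=O)OCc1ccccc1`, which carries a hydroxymethyl in place of hydrogen on a saturated chain carbon bound to an amide-type nitrogen and a carbonyl carbon, gives 29.2%. That is the higher of the two numbers, and the step of a number 12 percentage points higher from compound 1 to compound 2 (beyond the scatter) lies beyond the scatter, though it is modest.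

Compound 3 `O=C(CN(c1ncnc2c1ncn2C1CCCCO1)C1CC1)N[C@@H](CC(=O)OCc1ccccc1)C(=O)OCc1ccccc1` has not yet been measured. It differs from compound 2 in one place: benzyloxycarbonyl in place of hydroxy on a saturated chain carbon, two bonds along the chain from an amide-type nitrogen and a carbonyl carbon. Within the data shown here, no measured step covers this kind of exchange. Among the measured compounds shown here, the only step available, a number 12 percentage points higher from compound 1 to compound 2 (beyond the scatter), shows that a change at this part of the chain moves the read-out modestly, but it says nothing about replacing the hydroxy by a benzyloxycarbonyl. The direction of the step in this assay is therefore open, and a wide range is appropriate. Compound 3 is expected to give about 22%, between 8% and 40%. This estimate means a step of a number 7.2 percentage points lower from compound 2 to compound 3 (within the scatter), which is expected to stay within the scatter.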

Compound 3, a percentage reported as activity, at one dose (the size of the read-out at that dose, not a potency): 7.82%
The estimate for compound 3 lay 14.2 percentage points above the measured number, and the stated range ends above it.
By their numbers in this assay, from the lowest: compounds 3 and 1 (each within the scatter of the next); then compound 2.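

In this assay, the change from hydroxymethyl to (benzyloxycarbonyl)methyl on this chain carbon gives a number 21.4 percentage points lower from compound 2 to compound 3 (beyond the scatter), so the gain brought by hydroxymethyl does not extend to every group placed here. Measured against hydrogen at the same carbon, (benzyloxycarbonyl)methyl gives a number 9.4 percentage points lower from compound 1 to compound 3 (within the scatter), which means that adding a group at this place does not by itself raise the read-out, and that among these three compounds only compound 2 stands apart from the other two. Nothing available gives a reason for the difference between these groups.

On these data alone, it remains open how a carboxylic acid in place of benzyloxycarbonyl on the same chain carbon would read, and whether an aminomethyl, a methyl or a longer chain ending in hydroxy, such as 2-hydroxyethyl, would match hydroxymethyl or fall back towards hydrogen. Since only hydrogen, hydroxymethyl and (benzyloxycarbonyl)methyl are shown at this carbon, and all at one dose and one time point, it also remains open whether the hydroxy is what sets compound 2 apart.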